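This account rests on a few compounds, and the source may have more. Where it says the series, first, only, none or still open, it means among the compounds named here.

Among the measured compounds shown here, in a functional assay on MCF7 cells (Homo sapiens) for cytotoxicity, read by MTT assay, with a stated time of 24 h, tested at 1.6 ug/mL (on this read-out lower numbers stand for a weaker effect and higher numbers for a stronger effect at the one concentration tested), compound 2 `Cn1nnnc1SCC(=O)Nc1ccc(-c2nc(-c3ccccc3)c(-c3ccccc3)n2C)cc1` gives 34.3%, the top of the two numbers measured so far, though only by a step within the scatter: compound 1 `Cn1c(-c2ccc(NC(=O)CSc3nc4ccccc4o3)cc2)nc(-c2ccccc2)c1-c1ccccc1` gives 27.4%, and the step of a number 6.9 percentage points higher from compound 1 to compound 2 (within the scatter) is too small to separate them. Compound 3 `Cn1c(-c2ccc(NC(=O)CN3CCN(c4ccccc4)CC3)cc2)nc(-c2ccccc2)c1-c1ccccc1` has not yet been measured in this assay. It differs from compound 2 in one place: 4-phenylpiperazin-1-yl in place of (1-methyl-1H-tetrazol-5-yl)sulfanyl on a saturated chain carbon bound to a carbonyl carbon. For the measured compounds named here, the only measured step, a number 6.9 percentage points higher from compound 1 to compound 2 (within the scatter), put 1-methyl-1H-tetrazol-5-yl in place of 1,3-benzoxazol-2-yl on a sulfur and left the read-out essentially unchanged. That step does not probe the present change, in which the sulfur and the ring it carried both leave and 4-phenylpiperazin-1-yl enters. Going by the values given here, no measured step therefore bears directly on it, and no shift beyond the scatter is expected in either direction, with wide uncertainty. Compound 3 is estimated at 32%, within 12% to 55%, which corresponds to an expected a number 2.3 percentage points lower from compound 2 to compound 3 (within the scatter).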

Compound 3, a percentage reported as activity, at one concentration (the size of the read-out at that concentration, not a potency): 21.3%
For compound 3 the middle estimate is 10.7 percentage points above the measured one, and the stated range covers the measured number.
By their numbers in this assay, from the lowest: compounds 3, 1 and 2 (each within the scatter of the next, the first and the last beyond it).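

In this assay, among the compounds shown here, 4-phenylpiperazin-1-yl in place of (1-methyl-1H-tetrazol-5-yl)sulfanyl on a saturated chain carbon bound to a carbonyl carbon gives a number 13 percentage points lower from compound 2 to compound 3 (beyond the scatter) and is the first step here to clear the scatter, so the read-out can respond to a change at this position. The same group in place of (1,3-benzoxazol-2-yl)sulfanyl gives only a number 6.1 percentage points lower from compound 1 to compound 3 (within the scatter) and so separates nothing, which means the effect of this swap depends on the group replaced. No measurement available here explains the difference.

Because the sulfur and its ring leave together, these compounds cannot show which part of the change matters. A piperazine without the phenyl, a morpholine or a simple dimethylamino group at the same place would show whether the phenyl ring plays any part.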